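Methylsulfonyl in place of a lactam on compound 2

A few compounds are considered here, and "the series" means these few. Any claim that something is new, unique, unknown or untested is made for them only; others in the source may bear on it.

Measured in a physicochemical assay for lipophilicity, measured as octanol-water partition, at pH 7.4; on this read-out higher numbers stand for higher lipophilicity and lower numbers for lower lipophilicity:
- compound 1 `CCc1cnc(N2CCC(C(C)COC(=O)N3CCc4cc(S(C)(=O)=O)cc(F)c43)CC2)nc1`: 3.6
- compound 2 `CC(C)c1noc(N2CCC(Oc3cc(N4CCc5cc(N6CCCC6=O)ccc54)ncn3)CC2)n1`: 3.7

In this assay, compound 2 gives 3.7 and compound 1 gives 3.6, so the two lie within the usual scatter of each other. Compound 3 `CC(C)c1noc(N2CCC(Oc3cc(N4CCc5cc(S(C)(=O)=O)ccc54)ncn3)CC2)n1` keeps the rest of compound 2 but carries methylsulfonyl in place of 2-oxopyrrolidin-1-yl on an aromatic carbon. Among the compounds with values here, no measured pair shows this change. Compound 1 also carries methylsulfonyl and gives 3.6, but its core differs, so it offers only a loose guide. A small downward step, close to the scatter, is expected: a number 0.30 log units lower from compound 2 to compound 3 (within the scatter). For compound 3 the estimated value is 3.4, with an expected range from 3 to 3.8.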

Compound 3, distribution coefficient: 3.1
The estimate for compound 3 lay 0.30 log units above the measured number; the range from low to high includes it.
By their numbers in this assay, from the lowest: compound 3; then compounds 1 and 2 (each within the scatter of the next).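

In this assay, within the data shown here, the replacement of 2-oxopyrrolidin-1-yl by methylsulfonyl on this aromatic carbon gives a number 0.60 log units lower from compound 2 to compound 3 (beyond the scatter), the first reading of a change in one place. It shows that this position can move the number beyond the scatter, which the comparison of compound 1 and compound 2, differing in more than one place, could not show. No measurement here gives a reason for the step.

On these data alone, whether the step follows from methylsulfonyl itself or from the loss of the lactam ring remains open. A nitrile or a primary amide on the same aromatic carbon could help separate the two.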